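A Phenoxy Group on an Inactive Pair

The source may hold more compounds than are shown below. What is called first, only, known or untested is meant among the compounds shown, and "the series" means these compounds.

Measured in a functional assay for inhibition, with Homo sapiens as the target; on this read-out higher numbers stand for weaker inhibition and lower numbers for stronger inhibition:
Compound 1 `CC(C)Oc1c(C(=O)Nc2nn[nH]n2)sc2ccc(Cl)cc12`: > 100000 nM (a limit)
Compound 2 `CC(C)Oc1c(C(=O)Nc2nn[nH]n2)sc2ccccc12`: > 100000 nM (a limit)

Compound 2 has no exact number, only the limit > 100000 nM. The same holds for compound 1, so the evidence is simply (the limit of > 100000 nM in this assay, at which 2 of the 2 values shown sit). Compound 3 `CC(C)Oc1c(C(=O)Nc2nn[nH]n2)sc2ccc(Oc3ccccc3)cc12` differs from compound 2 in one place: phenoxy in place of hydrogen on an aromatic carbon. Among the measured compounds shown here, the only measured step that bears on this change is a step that the two limits leave unreadable from compound 1 to compound 2. That step swaps chloro and hydrogen on the core, and it offers no size to carry over. For the measured compounds named here, with no sized step to build on, the safest expectation in this assay is little change, with a modest chance of a readable number. The expected step is an at least 1.4-fold lower number from compound 2 to compound 3 (0.15 log units; that floor lies within the scatter). For compound 3 the estimate is 70000 nM, with an expected range from 10000 nM to 150000 nM.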

Compound 3, half-maximal inhibitory concentration: > 100000 nM
Compound 3: only a limit was reported (the forecaster's own chance of this, stated with the estimate: 65%); middle value at least 1.4-fold (0.15 log units) away from the limit.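

No step can be read among compound 1, compound 2 and compound 3, as each carries only a limit in this assay: the limit of > 100000 nM in this assay, at which 3 of the 3 values shown sit.

The compounds shown leave open how chloro, hydrogen and phenoxy on the shared core truly compare in this assay, and whether any group there would give a readable number.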